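Swapping the amide substituent for a dicarboxypropyl chain

A few compounds are considered here, and "the series" means these few. Any claim that something is new, unique, unknown or untested is made for them only; others in the source may bear on it.

Compound 2 `CCn1c(C(=O)N[C@H](CO)C(C)C)ccc1C(CC)(CC)c1ccc(OCS(=O)(=O)c2ccccc2)c(C)c1` gives 25500 nM in a functional assay on MCF7 cells (Homo sapiens) for antiproliferative activity, read by MTT assay, with a stated time of 24 h (on this read-out higher numbers stand for weaker inhibition and lower numbers for stronger inhibition), the higher of the two numbers here; compound 1 `CCn1c(C(=O)NCCO)ccc1C(CC)(CC)c1ccc(OCS(=O)(=O)c2ccccc2)c(C)c1` gives 15500 nM, and the step of a 1.6-fold higher number from compound 1 to compound 2 (0.22 log units; within the scatter) lies within the scatter. Compound 3 `CCn1c(C(=O)N[C@H](CCC(=O)O)C(=O)O)ccc1C(CC)(CC)c1ccc(OCS(=O)(=O)c2ccccc2)c(C)c1` carries the change (1,3-dicarboxypropyl in place of 1-(hydroxymethyl)-2-methylpropyl on an amide-type nitrogen). Among the measured compounds shown here, only that single step is available, and it concerns a different group, so no change beyond the scatter is expected, and a 1.0-fold lower number from compound 2 to compound 3 (0.01 log units; within the scatter) is estimated accordingly. For compound 3 the estimate is 25000 nM, with a likely range from 8000 nM to 80000 nM.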

Compound 3, half-maximal inhibitory concentration: > 50000 nM
Compound 3 ended at the assay's limit; the forecaster's own chance of this, stated with the estimate: 20%; middle value at least 2.0-fold (0.30 log units) from the limit.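

The value for compound 3 is a limit of this assay, not a number: the limit of > 50000 nM in this assay, at which 1 of the 3 values shown sits.

Among the compounds shown here, the 1,3-dicarboxypropyl chain in place of 2-hydroxyethyl on the amide-type nitrogen gives an at least 3.2-fold higher number from compound 1 to compound 3 (0.50 log units; beyond the scatter), the first step here beyond the scatter, so inhibition at this position can clearly weaken. Against the 1-(hydroxymethyl)-2-methylpropyl chain, the step reads an at least 1.9-fold higher number from compound 2 to compound 3 (0.29 log units; that floor lies within the scatter), and that floor alone fixes no size.

On these data alone, whether a single carboxylic acid on a shorter chain, or an amine, would weaken inhibition in the same way remains open. As far as these compounds go, the true value of compound 3 also remains unknown.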